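Bromo in place of chloro: a small expected step

This account rests on a few compounds, and the source may have more. Where it says the series, first, only, none or still open, it means among the compounds named here.

Compound 1 `Fc1ccc(CSc2nnc(-c3cnccn3)s2)cc1`: > 50000 nM
Compound 2 `Clc1ccc(CSc2nnc(-c3cnccn3)s2)cc1`: 18900 nM

Going by the values given here, in a functional assay on HeLa cells (Homo sapiens) for antiproliferative activity, read by MTT assay, with a stated time of 48 h (on this read-out lower numbers stand for stronger inhibition and higher numbers for weaker inhibition), compound 2 gives 18900 nM, the only true number so far. For compound 1 the entry > 50000 nM is a limit and not a number.

Compound 3 `Brc1ccc(CSc2nnc(-c3cnccn3)s2)cc1` has not yet been measured. It differs from compound 2 by bromo in place of chloro on an aromatic carbon.

Among the compounds with values here, only one measured step bears on this change: an at least 2.6-fold lower number from compound 1 to compound 2 (0.42 log units; beyond the scatter), with chloro in place of fluoro on an aromatic carbon. From the compounds shown here alone, its true size remains open, since one end rests on (the limit of > 50000 nM in this assay, at which 1 of the 2 values shown sits). One step cannot establish a trend, but the step in compound 2 of an at least 2.6-fold lower number from compound 1 to compound 2 (0.42 log units; beyond the scatter) suggests that a further exchange of this kind may lower the number slightly, perhaps by no more than the scatter.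

The expected change is a 1.4-fold lower number from compound 2 to compound 3 (0.13 log units; within the scatter). For compound 3 the estimated value in this assay is 14000 nM, with an expected range from 6000 nM to 35000 nM.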

Compound 3, half-maximal inhibitory concentration: 12400 nM
Compound 3: middle estimate off by 1.1-fold (0.05 log units), on the high side, within the range that was stated.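

In this assay, bromo in place of chloro on an aromatic carbon, para to a large group, gives a 1.5-fold lower number from compound 2 to compound 3 (0.18 log units; within the scatter), so at this position the two halogens cannot be told apart on this read-out. The earlier compounds shown here offered only the exchange of chloro for fluoro, and the new compound adds a second comparison with fluoro, an at least 4.0-fold lower number from compound 1 to compound 3 (0.60 log units; beyond the scatter), so that chloro and bromo now both stand apart from fluoro, while the exchange between them brings no change that can be told from the scatter. The true size of both steps from fluoro stays open, since compound 1 is recorded only as a limit and not as a number: the limit of > 50000 nM in this assay, at which 1 of the 3 values shown sits.

The compounds shown leave open whether a group other than a halogen, such as methoxy, an amine or a carboxylic acid, would give a value that stands apart from those of chloro and bromo at this position. They also leave open how any of these halogens would read at another place on the ring, or with the shared core changed.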